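Acyl variation on a shared core: Vero cell tolerance

A few compounds are considered here, and "the series" means these few. Any claim that something is new, unique, unknown or untested is made for them only; others in the source may bear on it.

Measured compounds in an ADME assay on Vero cells (Chlorocebus sabaeus) for cytotoxicity; a lower number here means that less compound is tolerated, a higher number that more compound is tolerated:
- compound 1 `CC(=O)c1c(Nc2ccc(F)cc2F)[nH]c2c(C(F)(F)F)cc(Cl)cc2c1=O` gives 7300 nM.
- compound 2 `CC(=O)c1c(Nc2ccc(F)c(F)c2F)[nH]c2c(F)cc(F)cc2c1=O` gives only a limit of the assay, > 25000 nM.
- compound 3 `CC(C)C(=O)c1c(Nc2ccc(F)c(F)c2F)[nH]c2c(F)cc(F)cc2c1=O` gives only a limit of the assay, > 25000 nM.

Among the measured compounds shown here, compound 1 holds the only number in this assay; the other two values sit at the limit of > 25000 nM in this assay, at which 2 of the 3 values shown sit. From compound 2 to compound 3 the change is isopropyl in place of methyl on a carbonyl carbon, and in this assay it gives a step that the two limits leave unreadable from compound 2 to compound 3. The difference between the core of compound 1 and the core of compound 2 is not broken down here.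

Compound 4 `CC(C)C(=O)c1c(Nc2ccc(F)cc2F)[nH]c2c(C(F)(F)F)cc(Cl)cc2c1=O` carries the same change on the core of compound 1: isopropyl in place of methyl on a carbonyl carbon. The measured pair shows the step only between two limits, so nothing read there sets its size. Compound 4 is therefore expected to stay near compound 1, with a step of a 1.2-fold higher number from compound 1 to compound 4 (0.07 log units; within the scatter) estimated in this assay. The value estimated for compound 4 is 8500 nM, with the expected range from 3000 nM to 25000 nM.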

Compound 4, half-maximal cytotoxic concentration: 7300 nM
Compound 4: the middle estimate sits 1.2-fold (0.07 log units) above what was measured; low and high end bracket the measured number.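

On the core of compound 1, isopropyl in place of methyl on a carbonyl carbon gives in this assay no change at the digits printed from compound 1 to compound 4 (within the scatter). The same change on the core of compound 2 cannot be read, because compound 2 and compound 3 each stand at a limit of the assay rather than at a number: the limit of > 25000 nM in this assay, at which 2 of the 4 values shown sit. So the change has a readable size on one core only, and nothing here shows whether that size carries over to the other core or holds as a rule for the series.

Open is how a longer chain or an amine on the same carbonyl carbon would read in this assay, since acetyl and isopropylcarbonyl are the only two acyl groups shown on either core. Also open, from the compounds shown here alone, is how each of the differences between the two cores bears on the read-out, as those differences are not broken down one at a time.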